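Isopropyl to hydrogen on two related cores

The source may report more compounds than this note shows. Statements on the series, on what has been measured and on what is new or still open speak of the compounds shown alone.

Compound 1 `COc1c(OC(C)C)cc2occ(-c3csc4ccccc34)c(=O)c2c1OC(C)C` and compound 2 `COc1c(OC(C)C)cc2occ(-c3csc4ccccc34)c(=O)c2c1O` share one core, while compound 3 `COc1c(OC(C)C)cc2c(c1OC(C)C)C(=O)/C(=C/c1csc3ccccc13)O2` and compound 4 `COc1c(OC(C)C)cc2c(c1O)C(=O)/C(=C/c1csc3ccccc13)O2` share another; the difference between the two cores is not broken down here. In a functional assay on A549 cells (Homo sapiens) for antiproliferative activity, read by sulforhodamine B assay, with a stated time of 72 h (on this read-out higher numbers stand for weaker inhibition and lower numbers for stronger inhibition), compound 1 gives 8900 nM and compound 2 gives 7200 nM, a step of a 1.2-fold lower number from compound 1 to compound 2 (0.09 log units; within the scatter) for the change (hydrogen in place of isopropyl on an oxygen on an aromatic ring). Compound 3 in this assay reaches only > 10000 nM, a limit of the assay and not a number; this is the limit of > 10000 nM in this assay, at which 1 of the 3 values shown sits. The same change, (hydrogen in place of isopropyl on an oxygen on an aromatic ring), leads from compound 3 to compound 4. Since the measured step of a 1.2-fold lower number from compound 1 to compound 2 (0.09 log units; within the scatter) stayed within the scatter, compound 4 is expected to sit near or at the limit of this assay, with an estimated 12000 nM (range 5000 nM to 30000 nM), which means an expected step that the limit leaves unreadable from compound 3 to compound 4.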

Compound 4, half-maximal inhibitory concentration: > 10000 nM
Compound 4: no number, only a limit; the forecaster's own chance of this, stated with the estimate: 60%; the middle value lies beyond the limit too.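

In this assay compound 3 and compound 4 both stand at a limit and not at a number, so no step between them can be read: the limit of > 10000 nM in this assay, at which 2 of the 4 values shown sit.

From the compounds shown here alone, whether isopropoxy to hydroxy shifts the activity on the core of compound 3 stays open.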